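Shortening the unsaturated chain on a thiadiazole glycoside amide

A few compounds are considered here, and "the series" means these few. Any claim that something is new, unique, unknown or untested is made for them only; others in the source may bear on it.

Measured so far:
Compound 1 `CCCCCCCCCCCCCC(=O)Nc1nnc(S[C@@H]2O[C@H](COC(C)=O)[C@H](OC(C)=O)[C@H](OC(C)=O)[C@H]2OC(C)=O)s1` — 61300 nM
Compound 2 `CCCCCCCC/C=C\CCCCCCCC(=O)Nc1nnc(S[C@@H]2O[C@H](CO)[C@H](O)[C@H](O)[C@H]2O)s1` — 8800 nM

Of the compounds shown here, two have been tested in a functional assay on HeLa cells (Homo sapiens) for cytotoxicity, read by MTT assay, with a stated time of 24 h; a lower number here means a stronger inhibitor, a higher number a weaker inhibitor. Compound 1 `CCCCCCCCCCCCCC(=O)Nc1nnc(S[C@@H]2O[C@H](COC(C)=O)[C@H](OC(C)=O)[C@H](OC(C)=O)[C@H]2OC(C)=O)s1` gives 61300 nM in this assay, and compound 2 `CCCCCCCC/C=C\CCCCCCCC(=O)Nc1nnc(S[C@@H]2O[C@H](CO)[C@H](O)[C@H](O)[C@H]2O)s1` gives 8800 nM. Compound 2 stands at the lower of the two numbers, with compound 1 as its nearest neighbour at a higher value, a gap that lies beyond the scatter. For the measured compounds named here, the two differ in more than one place, so no single step between them is drawn; only what their two values show is stated here.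

Compound 3 `C=CCCCCCCCCC(=O)Nc1nnc(S[C@@H]2O[C@H](CO)[C@H](O)[C@H](O)[C@H]2O)s1` has not yet been measured. It differs from compound 2 as follows: allyl in place of dec-1-en-1-yl on a saturated chain carbon, seven bonds along the chain from a carbonyl carbon. The saturated chain carbon carries allyl where compound 2 carries dec-1-en-1-yl.

Going by the values given here, no measured step resembles this change, so the expectation rests on compound 2 alone. The number for compound 3 is expected to move upward from compound 2, a step of a 2.8-fold higher number from compound 2 to compound 3 (0.45 log units; beyond the scatter) in this assay, modest and likely beyond the scatter. Compound 3 is therefore estimated at 25000 nM, within a range from 8000 nM to 80000 nM.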

Compound 3, half-maximal inhibitory concentration: 58300 nM
For compound 3 the middle estimate is 2.3-fold (0.37 log units) below the measured one; measured number inside the range.
By their numbers in this assay, from the lowest: compound 2; then compounds 3 and 1 (each within the scatter of the next).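

Replacing dec-1-en-1-yl with allyl, on a saturated chain carbon seven bonds along the chain from a carbonyl carbon, gives in this assay a step of a 6.6-fold higher number from compound 2 to compound 3 (0.82 log units; beyond the scatter), which shows that this far end of the chain is not indifferent to the group it carries: the weaker number goes with the shorter group. The leaving group has 10 heavy atoms and the entering group 3, while each has 1 double bond outside aromatic rings, so the count of double bonds does not change, although the double bond sits at a different point in the chain and the step cannot be assigned to chain length alone. Nothing measured on these compounds accounts for the step, so its cause remains unknown.

With a single step at this position, the compounds shown do not tell whether the number rises gradually or abruptly as the chain shortens, or whether a longer chain would lower it further. They also leave open how a fully saturated decyl group, or an amine or carboxylic acid at the chain end, would behave on the same core.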